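Piperazin-1-yl in place of ureido: next step

A few compounds are considered here, and "the series" means these few. Any claim that something is new, unique, unknown or untested is made for them only; others in the source may bear on it.

compound 1 (`N#Cc1c(O)nc(SCc2nc3ccccc3[nH]2)nc1-c1ccccc1`) gives 6.09 nM
compound 2 (`N#Cc1c(NC(N)=O)nc(SCc2nc3ccccc3[nH]2)nc1-c1ccccc1`) gives 2.5 nM

Among the compounds with values here, in a functional assay on RKOp27 cells (Homo sapiens) for cytotoxicity, read by MTT assay, with a stated time of 3 days (on this read-out lower numbers stand for stronger inhibition and higher numbers for weaker inhibition), compound 2 gives 2.5 nM as the lower of the two numbers so far. The next change puts piperazin-1-yl in place of ureido on an aromatic carbon, ortho to a cyano group, and leads to compound 3 (`N#Cc1c(-c2ccccc2)nc(SCc2nc3ccccc3[nH]2)nc1N1CCNCC1`). The counted difference is piperazin-1-yl in place of ureido on an aromatic carbon for this swap. Within the data shown here, one measured step bears on this carbon: a 2.4-fold lower number from compound 1 to compound 2 (0.39 log units; beyond the scatter) with ureido in place of hydroxy. That step is modest, and no group with a ring has been measured at this place. On that single step, a change of similar modest size is expected in this assay, toward a higher number, with the direction uncertain. The estimated move is a 2.0-fold higher number from compound 2 to compound 3 (0.30 log units; within the scatter) for this change. The estimate for compound 3 is 5 nM with an expected range from 1.5 nM to 17 nM in this read-out.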

Compound 3, half-maximal inhibitory concentration: 5.81 nM
Estimate against measurement, compound 3: 1.2-fold (0.07 log units) below, and the stated range covers the measured number.
By their numbers in this assay, from the lowest: compound 2; then compounds 3 and 1 (each within the scatter of the next).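

Piperazin-1-yl is the first group with a ring at this carbon, and in this assay replacing ureido with it gives a 2.3-fold higher number from compound 2 to compound 3 (0.37 log units; beyond the scatter) and leaves compound 2 with the lowest number of the three. Against hydroxy, the same ring gives a 1.0-fold lower number from compound 1 to compound 3 (0.02 log units; within the scatter) and so sets up no order between these two groups; of the three groups at this carbon, only ureido stands apart. No supporting data bear on why ureido stands apart from the other two groups.

From the compounds shown here alone, it remains open whether the second ring nitrogen of piperazin-1-yl matters, which a morpholine ring with oxygen in its place would address. An open-chain amine such as dimethylamino, or an acetamido group, would help separate the effect of the ring from that of the ureido carbonyl.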